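Capping a Phenol in a Diester Series

The source may report more compounds than this note shows. Statements on the series, on what has been measured and on what is new or still open speak of the compounds shown alone.

Three diesters of a shared core have been measured in an ADME assay on a cell-free system (plasma, Homo sapiens) for metabolic stability, with Plasma (Rattus norvegicus) as the target, read by HPLC, at pH 7.4; a lower number here means that the compound disappears faster, a higher number that the compound lasts longer. Compound 1 `CC(=O)Oc1ccccc1C(=O)O[C@H]1CO[C@H]2[C@@H]1OC[C@H]2OC(=O)c1ccnn1C` gives 0.0963 h, compound 2 `CC(=O)Oc1ccccc1C(=O)O[C@H]1CO[C@H]2[C@@H]1OC[C@H]2OC(=O)c1ccc(O)cc1` gives 0.0198 h, and compound 3 `CCC(=O)O[C@@H]1CO[C@H]2[C@@H]1OC[C@@H]2OC(=O)c1ccccc1OC(C)=O` gives 0.0608 h. Compound 2 is the lowest of the three: the step of a 4.9-fold lower number from compound 1 to compound 2 (0.69 log units; beyond the scatter) and the step of a 3.1-fold higher number from compound 2 to compound 3 (0.49 log units; beyond the scatter) both lie beyond the scatter, while a 1.6-fold lower number from compound 1 to compound 3 (0.20 log units; within the scatter) does not.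

Compound 4 `COc1ccc(C(=O)O[C@@H]2CO[C@H]3[C@@H]2OC[C@@H]3OC(=O)c2ccccc2OC(C)=O)cc1` has not yet been measured in this assay. It differs from compound 2 by methyl in place of hydrogen on an oxygen on an aromatic ring, that is, hydroxy becomes methoxy and 4-hydroxyphenyl becomes 4-methoxyphenyl on the carbonyl carbon.

Going by the values given here, no measured step changes only the hydrogen on that oxygen; the two steps that touch this position, a 4.9-fold lower number from compound 1 to compound 2 (0.69 log units; beyond the scatter) and a 3.1-fold higher number from compound 2 to compound 3 (0.49 log units; beyond the scatter), exchange the whole 4-hydroxyphenyl group for something else, and both show that compound 2 sits at the low end. Given that the change here is a single carbon with no ring and no donors or acceptors, a step smaller than those whole-group exchanges is expected, most likely upward from compound 2 but possibly within the scatter.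

The expected step is a 1.8-fold higher number from compound 2 to compound 4 (0.25 log units; within the scatter). Compound 4 is therefore estimated at 0.035 h, with a range from 0.015 h to 0.09 h.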

Compound 4, half-life: 0.0525 h
Beside the measured number, compound 4's estimate is 1.5-fold (0.18 log units) below it, within the range that was stated.
By their numbers in this assay, from the lowest: compound 2; then compounds 4, 3 and 1 (each within the scatter of the next).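

In this assay, going by these compounds alone, methyl in place of hydrogen on an oxygen on an aromatic ring is the first change that touches this position alone, and a 2.7-fold higher number from compound 2 to compound 4 (0.42 log units; beyond the scatter) shows that this single carbon is enough to carry the number beyond the scatter. Once the hydroxy has become methoxy, the 4-methoxyphenyl group no longer stands apart from the other groups on that carbonyl carbon: a 1.2-fold lower number from compound 3 to compound 4 (0.06 log units; within the scatter) and a 1.8-fold lower number from compound 1 to compound 4 (0.26 log units; within the scatter) are both printed as within the scatter, so among these four compounds only the one with the free hydroxy, compound 2, sits apart at the low end. Nothing available here bears on why the methyl has this effect.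

On these data alone, whether any cap on that oxygen gives the same step remains open, since a longer chain such as ethyl or propyl there cannot be compared with the methyl. As far as these compounds go, it is also open how an amine or a carboxylic acid in place of the hydroxy on the same ring would compare with compound 2 and compound 4.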